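Replacing the 3,4-dimethoxyphenyl group of compound 2

The source may hold more compounds than are shown below. What is called first, only, known or untested is meant among the compounds shown, and "the series" means these compounds.

In a functional assay on MCF7 cells (Homo sapiens) for antiproliferative activity, read by sulforhodamine B assay, with a stated time of 48 h (on this read-out lower numbers stand for stronger inhibition and higher numbers for weaker inhibition), compound 1 (`COc1ccc(/C=C/C(=O)c2ccccc2-c2ccc(OC)c(OC)c2)cc1`) gives 1100 nM, compound 2 (`COc1ccc(/C=C/C(=O)c2ccccc2-c2ccc(OC)c(OC)c2)cc1OC`) gives 4900 nM, and compound 3 (`COc1ccc(-c2ccccc2C(=O)/C=C/c2ccc(Br)cc2)cc1OC`) gives 8300 nM. The place of compound 2 in this small set is fixed by two steps: a 1.7-fold higher number from compound 2 to compound 3 (0.23 log units; within the scatter), and a 4.5-fold higher number from compound 1 to compound 2 (0.65 log units; beyond the scatter).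

Compound 4 (`COc1ccc(/C=C/C(=O)c2ccccc2-c2ccc(F)nc2)cc1OC`) departs from compound 2 at a different site: 6-fluoropyridin-3-yl in place of 3,4-dimethoxyphenyl on an aromatic carbon. Within the data shown here, the group that leaves, 3,4-dimethoxyphenyl, is present in compound 1, compound 2 and compound 3 alike, so no measured step tests this change directly. Among the measured compounds shown here, the only guide is indirect, from changes made elsewhere in the molecule, the largest being a 7.5-fold higher number from compound 1 to compound 3 (0.88 log units; beyond the scatter). A step of similar modest size is therefore the most that can reasonably be expected, and the data suggest no firm direction. The estimated change is a 1.2-fold higher number from compound 2 to compound 4 (0.09 log units; within the scatter), which means no expected step beyond the scatter. For compound 4, the expected value is 6000 nM, with an estimated range from 1800 nM to 20000 nM.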

Compound 4, half-maximal inhibitory concentration: 2800 nM
The estimate for compound 4 lay 2.1-fold (0.33 log units) above the measured number; the measured number falls inside the stated range.
By their numbers in this assay, from the lowest: compound 1; then compounds 4, 2 and 3 (each within the scatter of the next, the first and the last beyond it).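

Among these compounds, compound 4 is the first compound here to change the 3,4-dimethoxyphenyl group, on the aromatic carbon ortho to a large group, and in this assay 6-fluoropyridin-3-yl in its place gives a 1.8-fold lower number from compound 2 to compound 4 (0.24 log units; within the scatter). The step lies within the scatter, so the two methoxy groups and the all-carbon ring are not needed to keep the number at the level of compound 2: a group with fewer heavy atoms, a ring nitrogen and a fluorine reads the same. No measurement at hand says why these two groups read alike.

A 4-fluorophenyl or an unsubstituted pyridin-3-yl group at this place would be needed to separate the fluorine from the ring nitrogen. As far as these compounds go, it also remains open whether 6-fluoropyridin-3-yl behaves the same way with the 4-methoxyphenyl end of compound 1.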